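Chloropyridine amides in the benzothiazole series: permeability notes

A few compounds are considered here, and "the series" means these few. Any claim that something is new, unique, unknown or untested is made for them only; others in the source may bear on it.

The shared core carries an amide on the aryl ring, and the acyl part varies. Compound 1 `O=C(O)/C=C/C(=O)Nc1cccc(-c2nc3ccccc3s2)c1` carries the 2-carboxyethenyl group on the carbonyl carbon. Among the compounds with values here, in an ADME assay for permeability, using PAMPA (a higher number here means that the compound crosses the layer faster, a lower number that the compound crosses the layer more slowly), compound 1 gives 4 10^-6 cm/s, the lowest of the two numbers measured so far. Compound 2 `O=C(Nc1cccc(-c2nc3ccccc3s2)c1)c1ccnc(Cl)c1` carries 2-chloropyridin-4-yl in its place, and in this assay compound 2 gives 478 10^-6 cm/s; the step of a 120-fold higher number from compound 1 to compound 2 (2.08 log units; beyond the scatter) is the only measured one and is large. Compound 3 `O=C(Nc1cccc(-c2nc3ccccc3s2)c1)c1ccncc1Cl` is the unmeasured isomer: 3-chloropyridin-4-yl in place of 2-carboxyethenyl on a carbonyl carbon. The change removes the same 2-carboxyethenyl group and puts in a chloropyridine differing from compound 2 only in where the chlorine sits on the ring. The step to compound 2 bears directly on this, so a large upward step is expected for compound 3 in this assay, namely a 100-fold higher number from compound 1 to compound 3 (2.00 log units; beyond the scatter). The expected value for compound 3 is 400 10^-6 cm/s, within 150 10^-6 cm/s to 900 10^-6 cm/s.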

Compound 3, apparent permeability in the ADME assay: 563 10^-6 cm/s
Compound 3: the middle estimate sits 1.4-fold (0.15 log units) below what was measured; measured number inside the range.
By their numbers in the ADME assay, from the lowest: compound 1; then compounds 2 and 3 (each within the scatter of the next).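

In the ADME assay 3-chloropyridin-4-yl in place of 2-chloropyridin-4-yl on the carbonyl carbon gives a 1.2-fold higher number from compound 2 to compound 3 (0.07 log units; within the scatter), so the two chloropyridine isomers cannot be told apart here. The large rise seen with compound 2 thus recurs with a second chloropyridine, as a 140-fold higher number from compound 1 to compound 3 (2.15 log units; beyond the scatter). In a physicochemical assay for solubility, in phosphate buffer, measured as kinetic solubility, with a stated time of 18 h, at pH 7.4 (a lower number here means a less soluble compound, a higher number a more soluble compound), compound 1 gives 56000 nM and compound 3 gives 320 nM. The same replacement of 2-carboxyethenyl comes with a large fall in the physicochemical assay as well, as follows: the measured solubility of compound 1, 56000 nM, and of compound 3, 320 nM, a 180-fold lower number (2.24 log units; beyond the scatter).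

Still open, on these data alone, is what a plain pyridin-4-yl, a phenyl or an aminopyridine group on the carbonyl carbon would give in the ADME assay and in the physicochemical assay, and so whether the chlorine has any part in either step. Nor do the compounds shown tell whether any acyl group can pair a number like that of compound 3 in the ADME assay with one like that of compound 1 in the physicochemical assay.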